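The source may report more compounds than this note shows. Statements on the series, on what has been measured and on what is new or still open speak of the compounds shown alone.

Three adenosine-derived compounds have been tested in an assay on COS-7 cells for inhibition of sodium/nucleoside cotransporter 2 (Homo sapiens), read by scintillation counting, in the presence of a further agent that is not named here; on this read-out higher numbers stand for weaker inhibition and lower numbers for stronger inhibition. Compound 1 `Nc1ncnc2c1ncn2[C@@H]1O[C@H](COC(=O)OCc2ccccc2)[C@@H](O)[C@H]1O` gives only a limit of the assay in this assay, > 100000 nM. Compound 2 `CC(=O)OC[C@H]1O[C@@H](n2cnc3c(N)ncnc32)[C@H](O)[C@@H]1O` likewise reaches only a limit of the assay, > 100000 nM. Compound 3 `Nc1ncnc2c1nc(NCCCc1ccccc1)n2[C@@H]1O[C@H](CO)[C@@H](O)[C@H]1O` gives 536000 nM in this assay. Going by the values given here, the one step measured between neighbours, a step that the two limits leave unreadable from compound 1 to compound 2, cannot be sized, since both of its ends are limits; the limit of > 100000 nM in this assay, at which 2 of the 3 values shown sit, shows where those two ends sit. Among the compounds with values here, compound 2 therefore stands at the limit, with no measured step that places it relative to compound 1, and only compound 3 stands beyond that limit as a number.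

Compound 4 `CCOC(=O)OC[C@H]1O[C@@H](n2cnc3c(N)ncnc32)[C@H](O)[C@@H]1O` differs from compound 2 by ethoxy in place of methyl on a carbonyl carbon. Within the data shown here, no measured step bears directly on this change, and the only step at the same carbonyl carbon is unreadable. With no evidence of a shift in either direction, compound 4 is expected to remain at or beyond the limit, so the step that the limit leaves unreadable from compound 2 to compound 4 is estimated to lie within the scatter. The estimate for compound 4 in this assay is 200000 nM, in the range 80000 nM to 1000000 nM.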

Compound 4, half-maximal inhibitory concentration: > 100000 nM
Compound 4: no number, only a limit; the forecaster's own chance of this, stated with the estimate: 80%; the middle value lies beyond the limit too.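

Compound 4 gives only a limit of the assay in this assay, > 100000 nM. Its steps from compound 1 and compound 2 therefore cannot be read, and all three compounds sit at the same limit: the limit of > 100000 nM in this assay, at which 3 of the 4 values shown sit. The compounds shown leave open whether ethoxy in place of methyl on a carbonyl carbon changes inhibition at all.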